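Ester chain length and cytotoxicity across four compounds

The compounds below may be only part of what the source reports. "The series", "measured", "known", "first", "only" and "open" are said of these compounds alone.

Compound 1 `CCCCCCOC(=O)CCC(=O)N1CCN(CCCOc2cc3c(Nc4ccc(F)c(Cl)c4)ncnc3cc2OC)CC1` is the reference point of the set. In a functional assay on A549 cells (Homo sapiens) for cytotoxicity, read by MTT assay, with a stated time of 24 h, tested at 80 uM (a higher number here means a weaker effect of the compound at the concentration tested, a lower number a stronger effect), compound 1 gives 42.9%. Compound 2 `CCCCCCCOC(=O)CCC(=O)N1CCN(CCCOc2cc3c(Nc4ccc(F)c(Cl)c4)ncnc3cc2OC)CC1` differs from it by methyl in place of hydrogen on a saturated chain carbon, six bonds along the chain from an oxygen next to a carbonyl group; in this assay compound 2 gives 27.2%, the step being a number 15.7 percentage points lower from compound 1 to compound 2 (beyond the scatter). Compound 3 `CCCCCCCCCCCCCCCCOC(=O)CCC(=O)N1CCN(CCCOc2cc3c(Nc4ccc(F)c(Cl)c4)ncnc3cc2OC)CC1` differs from compound 1 by decyl in place of hydrogen on a saturated chain carbon, six bonds along the chain from an oxygen next to a carbonyl group. In this assay compound 3 gives 74.3%, the highest of the three, with a number 31.4 percentage points higher from compound 1 to compound 3 (beyond the scatter) and a number 47.1 percentage points higher from compound 2 to compound 3 (beyond the scatter).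

Compound 4 `CCCCCCCCCCCCCCCCCOC(=O)CCC(=O)N1CCN(CCCOc2cc3c(Nc4ccc(F)c(Cl)c4)ncnc3cc2OC)CC1` has not yet been measured in this assay. It differs from compound 3 by methyl in place of hydrogen on a saturated chain carbon, ten or more bonds along the chain from an oxygen next to a carbonyl group. For the measured compounds named here, this is the same kind of change as the one from compound 1 to compound 2, but the place along the chain from an oxygen next to a carbonyl group is not the same. Whether a single added methyl on a chain already as long as that of compound 3 moves the number is not shown by these data. Going by the values given here, the expected step is a number 2.3 percentage points lower from compound 3 to compound 4 (within the scatter), kept small because a number 15.7 percentage points lower from compound 1 to compound 2 (beyond the scatter) is the only comparable step and runs opposite to a number 31.4 percentage points higher from compound 1 to compound 3 (beyond the scatter). The estimate for compound 4 in this assay is 72%, expected between 56% and 88%.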

Compound 4, a percentage reported as activity, at one concentration (the size of the read-out at that concentration, not a potency): 83.2%
Compound 4: middle estimate off by 11.2 percentage points, on the low side; the range from low to high includes it.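

In this assay the methyl step does not carry over from one chain length to the other, and a number 8.9 percentage points higher from compound 3 to compound 4 (within the scatter) stands apart from the earlier step on the shorter chain: the same change on two cores in this assay, a number 15.7 percentage points lower (beyond the scatter) from compound 1 to compound 2 and a number 8.9 percentage points higher (within the scatter) from compound 3 to compound 4, 24.6 percentage points apart, beyond the scatter of two such steps. The decyl and undecyl additions point the same way, with a number 56 percentage points higher from compound 2 to compound 4 (beyond the scatter) and a number 40.3 percentage points higher from compound 1 to compound 4 (beyond the scatter), but the size of such a step depends on the chain it starts from: the same change on two cores in this assay, a number 31.4 percentage points higher (beyond the scatter) from compound 1 to compound 3 and a number 56 percentage points higher (beyond the scatter) from compound 2 to compound 4, 24.6 percentage points apart, beyond the scatter of two such steps. This shows that a chain change read on one member of these four compounds cannot simply be transferred to another, while it does not show how the number behaves at any other chain length, nor what it would be at another concentration, as each value is a single read-out and not a potency.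

Going by these compounds, the span from the heptyl ester of compound 2 to the much longer ester of compound 3 remains open, so an octyl or dodecyl ester could show where the number turns upward. On these data alone, a branched chain or a carboxylic acid in place of the ester also remains open.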